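Trifluoromethyl in place of chloro on the urea aryl ring

This account rests on a few compounds, and the source may have more. Where it says the series, first, only, none or still open, it means among the compounds named here.

Two compounds of the series have numbers in a functional assay on MDA-MB-468 cells (Homo sapiens) for inhibition, read by sulforhodamine B assay, with a stated time of 48 h; on this read-out higher numbers stand for weaker inhibition and lower numbers for stronger inhibition. Compound 1 `O=C(Nc1cccc(-n2cc(-c3ccncc3)c(-c3ccc(Cl)c(O)c3)n2)c1)Nc1ccc(Cl)c(Cl)c1` gives 730 nM in this assay. Compound 2 `COc1cc(-c2nn(-c3cccc(NC(=O)c4cccc(C(F)(F)F)c4)c3)cc2-c2ccncc2)ccc1Cl` gives 1320 nM in this assay; the two numbers lie within the scatter of each other, so neither compound can be set apart from the other on these data. Compound 1 is the reference for the step that follows. Compound 3 `O=C(Nc1cccc(-n2cc(-c3ccncc3)c(-c3ccc(Cl)c(O)c3)n2)c1)Nc1ccc(Cl)c(C(F)(F)F)c1` has not been measured; it differs from compound 1 by trifluoromethyl in place of chloro on an aromatic carbon. Within the data shown here, no step between two measured compounds is available to guide the size of this change, and compound 2 differs from both in several places at once. With nothing pointing to a shift beyond the scatter, the expected step is a 1.2-fold lower number from compound 1 to compound 3 (0.09 log units; within the scatter), a movement that stays within the scatter in either direction. Compound 3 is estimated at 600 nM in this assay, with a range from 250 nM to 1500 nM.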

Compound 3, half-maximal inhibitory concentration: 540 nM
Beside the measured number, compound 3's estimate is 1.1-fold (0.05 log units) above it; measured number inside the range.
By their numbers in this assay, from the lowest: compounds 3, 1 and 2 (each within the scatter of the next, the first and the last beyond it).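

Among these compounds, this is the first step that changes one group alone: a 1.4-fold lower number from compound 1 to compound 3 (0.13 log units; within the scatter) in this assay, with trifluoromethyl in place of chloro on an aromatic carbon. At this carbon, ortho to a chloro group, going from 1 heavy atom to 4 heavy atoms produces no shift beyond the scatter, so 3,4-dichlorophenyl and 4-chloro-3-(trifluoromethyl)phenyl cannot be told apart on this read-out. No measurement shown here bears on the reason for this result.

From the compounds shown here alone, it remains open whether a nitrile, an amine or a carboxylic acid at this carbon would also stay within the scatter of compound 1. Compound 2 differs from compound 3 in several places, so it gives no separate reading on this change.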